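Swapping the aryl on the sulfonyl: compound 1 to compound 3

The compounds below may be only part of what the source reports. "The series", "measured", "known", "first", "only" and "open" are said of these compounds alone.

For the measured compounds named here, compound 1 `O=C1O[C@H]([C@@H](O)Cn2cc(CNS(=O)(=O)c3ccc(F)cc3)nn2)C(OCc2ccccc2)=C1OCc1ccccc1` gives 30 nM in an ADME assay on HFF cells (Homo sapiens) for cytotoxicity, read by MTT assay, with a stated time of 72 h (on this read-out higher numbers stand for weaker inhibition and lower numbers for stronger inhibition), the lowest of the two numbers known; compound 2 `O=C1O[C@H]([C@@H](O)Cn2cc(C3CC3)nn2)C(OCc2ccccc2)=C1OCc1ccccc1` gives 24300 nM, and the step of an 810-fold higher number from compound 1 to compound 2 (2.91 log units; beyond the scatter) is large. Compound 3 `O=C1O[C@H]([C@@H](O)Cn2cc(CNS(=O)(=O)c3ccc(Cl)cc3F)nn2)C(OCc2ccccc2)=C1OCc1ccccc1` differs from compound 1 by 4-chloro-2-fluorophenyl in place of 4-fluorophenyl on a sulfonyl sulfur. Going by the values given here, no measured step touches this position: the one step known removes the whole (((4-fluorophenyl)sulfonyl)amino)methyl arm rather than altering its aryl. Compound 3 is therefore expected to stay near compound 1, with a step of a 1.2-fold higher number from compound 1 to compound 3 (0.07 log units; within the scatter) that should lie within the scatter. The estimate for compound 3 is 35 nM, between 10 nM and 120 nM.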

Compound 3, half-maximal inhibitory concentration: 20 nM
For compound 3 the middle estimate is 1.8-fold (0.24 log units) above the measured one; the range from low to high includes it.
By their numbers in this assay, from the lowest: compounds 3 and 1 (each within the scatter of the next); then compound 2.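

In this assay, 4-chloro-2-fluorophenyl takes the place of 4-fluorophenyl on the sulfonyl sulfur with (a 1.5-fold lower number from compound 1 to compound 3 (0.18 log units; within the scatter)). The earlier step had removed the whole arm, whereas this one shows that the aryl can carry this exchange, with its added chlorine, and the result stays within the scatter. The compounds shown leave open whether the same holds for an amine or a carboxylic acid on that aryl, or for an alkyl chain in place of the aryl. Nothing available explains this result.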